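The compounds below may be only part of what the source reports. "The series", "measured", "known", "first", "only" and "open" are said of these compounds alone.

The measured compounds in a functional assay on CCRF-CEM cells (Homo sapiens); a higher number here means that more compound is tolerated, a lower number that less compound is tolerated:
compound 1 `COC(=O)CCNC1=CS(=O)(=O)O[C@@]12[C@@H](CO[Si](C)(C)C(C)(C)C)O[C@@H](n1cc(C)c(=O)n(C)c1=O)[C@@H]2O[Si](C)(C)C(C)(C)C`, > 250000 nM (a limit of the assay)
compound 2 `Cc1cn([C@@H]2O[C@H](CO[Si](C)(C)C(C)(C)C)[C@@]3(OS(=O)(=O)C=C3NCC(=O)C(=O)N3CCC3)[C@H]2O[Si](C)(C)C(C)(C)C)c(=O)n(C)c1=O`, 21600 nM
compound 3 `CC(=O)NC1=CS(=O)(=O)O[C@@]12[C@@H](CO[Si](C)(C)C(C)(C)C)O[C@@H](n1cc(C)c(=O)n(C)c1=O)[C@@H]2O[Si](C)(C)C(C)(C)C`, 25700 nM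

Compound 3 gives the higher of the two numbers at hand, though its gap to compound 2 is within the scatter, as a 1.2-fold higher number from compound 2 to compound 3 (0.08 log units; within the scatter) shows. The value of compound 1 is a limit of the assay, not a number. Compound 4 `COC(=O)NC1=CS(=O)(=O)O[C@@]12[C@@H](CO[Si](C)(C)C(C)(C)C)O[C@@H](n1cc(C)c(=O)n(C)c1=O)[C@@H]2O[Si](C)(C)C(C)(C)C` differs from compound 3 by methoxy in place of methyl on a carbonyl carbon. For the measured compounds named here, two measured steps touch the acetyl on the amine nitrogen: an at least 9.7-fold lower number from compound 1 to compound 3 (0.98 log units; beyond the scatter) and a 1.2-fold higher number from compound 2 to compound 3 (0.08 log units; within the scatter). The first is large, but it rests on the limit of > 250000 nM in this assay, at which 1 of the 3 values shown sits, and exchanges a far larger group; the second swaps one carbonyl-bearing group for another and stays within the scatter. The present change adds only a methoxy in place of a methyl on the carbonyl carbon, so in this assay the step expected for compound 4 is a 1.2-fold higher number from compound 3 to compound 4 (0.07 log units; within the scatter), nothing beyond the scatter. Compound 4 is therefore estimated at 30000 nM, between 12000 nM and 75000 nM.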

Compound 4, half-maximal cytotoxic concentration: 30700 nM
Compound 4: middle estimate off by 1.0-fold (0.01 log units), on the low side; measured number inside the range.
By their numbers in this assay, from the lowest: compounds 2, 3 and 4 (each within the scatter of the next). At a limit, above all of these: compound 1.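

In this assay, methoxy in place of methyl on a carbonyl carbon whose other neighbour is an amide-type nitrogen stays within the scatter: a 1.2-fold higher number from compound 3 to compound 4 (0.08 log units; within the scatter). Methoxycarbonyl on the amine nitrogen also stays within the scatter of the much larger group carried by compound 2, a 1.4-fold higher number from compound 2 to compound 4 (0.15 log units; within the scatter), so the three carbonyl-bearing groups of compounds 2, 3 and 4 cannot be told apart in this assay. Only compound 1, with its 2-(methoxycarbonyl)ethyl group, stands apart, an at least 8.1-fold lower number from compound 1 to compound 4 (0.91 log units; beyond the scatter), and its value is a limit of the assay: the limit of > 250000 nM in this assay, at which 1 of the 4 values shown sits.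

As far as these compounds go, it stays open whether an amine or a longer chain on this carbonyl carbon would move the number beyond the scatter. The compounds shown also do not tell whether a carboxylic acid in place of the ester at the end of the chain of compound 1 would bring a measurable number.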